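The source may hold more compounds than are shown below. What is called first, only, known or untested is meant among the compounds shown, and "the series" means these compounds.

Compound 1 `COc1ncnc2c1c(-c1ccsc1)cn2[C@@H]1O[C@H](CO)[C@@H](O)[C@H]1O` gives 75300 nM in an ADME assay on MRC5 cells (Homo sapiens), read by MTT assay, with a stated time of 72 h; a higher number here means a weaker inhibitor, a lower number a stronger inhibitor. Compound 2 `CN(C)c1ncnc2c1c(-c1ccsc1)cn2[C@@H]1O[C@H](CO)[C@@H](O)[C@H]1O` carries dimethylamino in place of methoxy on an aromatic carbon; in this assay compound 2 reaches only the limit > 100000 nM, so that value is a boundary rather than a number. That change made an at least 1.3-fold higher number from compound 1 to compound 2 (0.12 log units; that floor lies within the scatter), which is tied to the limit of > 100000 nM in this assay, at which 1 of the 3 values shown sits. Compound 3 `COc1ncnc2c1c(-c1ccoc1)cn2[C@@H]1O[C@H](CO)[C@@H](O)[C@H]1O` differs from compound 1 by furan-3-yl in place of thiophen-3-yl on an aromatic carbon, and in this assay compound 3 gives 29400 nM, a step of a 2.6-fold lower number from compound 1 to compound 3 (0.41 log units; beyond the scatter).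

Compound 4 `CN(C)c1ncnc2c1c(-c1ccoc1)cn2[C@@H]1O[C@H](CO)[C@@H](O)[C@H]1O` is not yet measured. It differs from compound 3 by dimethylamino in place of methoxy on an aromatic carbon, the same change that separates compound 1 from compound 2, on a core that differs by furan-3-yl in place of thiophen-3-yl on an aromatic carbon. Because compound 1 to compound 2 gave an at least 1.3-fold higher number from compound 1 to compound 2 (0.12 log units; that floor lies within the scatter), the expected step is a 2.0-fold higher number from compound 3 to compound 4 (0.31 log units; beyond the scatter). Compound 4 is therefore estimated at 60000 nM, with a range expected from 28000 nM to 130000 nM.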

Compound 4, half-maximal inhibitory concentration: > 100000 nM
Compound 4: no number, only a limit; the forecaster's own chance of this, stated with the estimate: 35%; middle value at least 1.6-fold (0.22 log units) from the limit.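

In this assay compound 4 reaches only a limit, > 100000 nM, so this value is a boundary and not a number. Dimethylamino in place of methoxy gives an at least 3.4-fold higher number from compound 3 to compound 4 (0.53 log units; beyond the scatter), which shows no reversal on the core of compound 3 but does not show whether the size of the change carries over from the core of compound 1: the same change on two cores in this assay, an at least 1.3-fold higher number (0.12 log units; that floor lies within the scatter) from compound 1 to compound 2 and an at least 3.4-fold higher number (0.53 log units; beyond the scatter) from compound 3 to compound 4; the limit leaves it open whether they differ. The step from compound 2 to compound 4 cannot be read, as both compounds sit at the limit: the limit of > 100000 nM in this assay, at which 2 of the 4 values shown sit.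

The compounds shown leave open how methylamino or ethoxy in the same place would read in this assay. They also leave open whether phenyl in place of furan-3-yl would lower the number further.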